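The source may report more compounds than this note shows. Statements on the series, on what has been measured and on what is new or still open speak of the compounds shown alone.

The measured compounds are:

compound 1 `N#C/C(=C\C=C(/Cl)c1ccc(Br)cc1)C(=O)c1c[nH]c2ccccc12`, which in a functional assay on MCF7 cells (Homo sapiens) for cytotoxicity, read by sulforhodamine B assay, with a stated time of 48 h (on this read-out lower numbers stand for stronger inhibition of growth and higher numbers for weaker inhibition of growth), gives 72500 nM
compound 2 `COc1ccc(/C(Cl)=C/C=C(\C#N)C(=O)c2c[nH]c3ccccc23)cc1OC`, which in this assay gives 44200 nM
compound 3 `COc1ccc(/C(Cl)=C/C=C(\C#N)C(=O)c2c[nH]c3ccc(Br)cc23)cc1OC`, which in this assay gives 31900 nM

Compound 1 and compound 2 carry different cores; the difference between the two cores is not broken down here. Compound 2 and compound 3 differ in one place only: bromo in place of hydrogen on an aromatic carbon. In this assay this change produced a 1.4-fold lower number from compound 2 to compound 3 (0.14 log units; within the scatter).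

Compound 4 `N#C/C(=C\C=C(/Cl)c1ccc(Br)cc1)C(=O)c1c[nH]c2ccc(Br)cc12` has not yet been measured in this assay. It is made from compound 1 by the change (bromo in place of hydrogen on an aromatic carbon), the same change that separates compound 2 from compound 3, at a place described in the same words. Among the measured compounds shown here, because the only example of this change gave a 1.4-fold lower number from compound 2 to compound 3 (0.14 log units; within the scatter), the step from compound 1 to compound 4 is expected to be of a similar, small size, a 1.4-fold lower number from compound 1 to compound 4 (0.14 log units; within the scatter), with the usual uncertainty of a single precedent on a different core. Compound 4 is therefore estimated at 52000 nM in this assay, most likely somewhere between 25000 nM and 110000 nM.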

Compound 4, concentration for 50% growth inhibition: > 100000 nM
Compound 4 ended at the assay's limit (the forecaster's own chance of this, stated with the estimate: 5%); at least 1.9-fold (0.28 log units) between middle value and limit.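

In this assay compound 4 gives > 100000 nM, which is a limit of the assay and not a number. Bromo in place of hydrogen on an aromatic carbon therefore leaves only a floor for the step on this core, an at least 1.3-fold higher number from compound 1 to compound 4 (0.13 log units; that floor lies within the scatter), and it shows that the change gave no lower number here. It does not show that the change behaves differently on the two cores, so the single earlier example can be neither confirmed nor ruled out as a guide for this one: the same change on two cores in this assay, a 1.4-fold lower number (0.14 log units; within the scatter) from compound 2 to compound 3 and an at least 1.3-fold higher number (0.13 log units; that floor lies within the scatter) from compound 1 to compound 4; the limit leaves it open whether they differ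

The compounds shown compare only hydrogen and bromo at this place, with one pair on each core, so how an amine or a carboxylic acid on the same aromatic carbon would read remains open. Also open, as far as these compounds go, is whether this change would give steps of a similar size on further cores, or on any core in another kind of cell.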